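The compounds below may be only part of what the source reports. "The series", "measured", "known", "first", "only" and "open" are said of these compounds alone.

Three compounds have so far been measured in a functional assay on MCF7 cells (Homo sapiens) for antiproliferative activity, read by MTT assay, with a stated time of 72 h; on this read-out lower numbers stand for stronger inhibition and higher numbers for weaker inhibition:

Compound 1, `COc1cc(-c2nc(N(C)C)sc2-c2ccc3ccccc3c2)cc(OC)c1OC`, gives 2390 nM.
Compound 2, `COc1cc(-c2nc(N(C)C)sc2-c2ccc(C)cc2)cc(OC)c1OC`, gives only a limit of the assay, > 10000 nM, not a number.
Compound 3, `COc1cc(-c2nc(C)sc2-c2ccc3ccccc3c2)cc(OC)c1OC`, gives 33.4 nM.

Compound 1 and compound 2 share a core and differ in one place: 4-methylphenyl in place of naphthalen-2-yl on an aromatic carbon. That change made an at least 4.1-fold higher number from compound 1 to compound 2 (0.62 log units; beyond the scatter). The value of compound 2 is a limit of the assay, (the limit of > 10000 nM in this assay, at which 1 of the 3 values shown sits).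

Compound 1 and compound 3 differ by methyl in place of dimethylamino on an aromatic carbon. That change made a 72-fold lower number from compound 1 to compound 3 (1.85 log units; beyond the scatter).

Compound 4, `COc1cc(-c2nc(C)sc2-c2ccc(C)cc2)cc(OC)c1OC`, has not yet been measured. It differs from compound 2 by methyl in place of dimethylamino on an aromatic carbon. Among the compounds with values here, this is the same kind of change as the one from compound 1 to compound 3, not the same: around the place, the ring atom two ring bonds away bears a 4-methylphenyl group (7 heavy atoms) in compound 2 and compound 4, whereas in compound 1 and compound 3 it bears a naphthalen-2-yl group.

For compound 4 the expected step in this assay is an at least 20-fold lower number from compound 2 to compound 4 (1.30 log units; beyond the scatter). Within the data shown here, that expectation rests on a 72-fold lower number from compound 1 to compound 3 (1.85 log units; beyond the scatter), the only measured instance of this kind of change. The starting point is uncertain for compound 2 because only a limit is known, (the limit of > 10000 nM in this assay, at which 1 of the 3 values shown sits), so the step may be larger than it appears. Compound 4 is therefore estimated at 500 nM, expected to fall between 100 nM and 5000 nM.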

Compound 4, half-maximal inhibitory concentration: 1740 nM
Compound 4: the middle estimate sits 3.5-fold (0.54 log units) below what was measured; low and high end bracket the measured number.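

In this assay, methyl in place of dimethylamino again goes with a lower number on the core that carries 4-methylphenyl, an at least 5.7-fold lower number from compound 2 to compound 4 (0.75 log units; beyond the scatter), so the direction of this change carries over from one core to the other: the same change on two cores in this assay, a 72-fold lower number (1.85 log units; beyond the scatter) from compound 1 to compound 3 and an at least 5.7-fold lower number (0.75 log units; beyond the scatter) from compound 2 to compound 4; the limit leaves it open whether they differ

Compound 2 gives > 10000 nM, which is a limit of the assay and not a number. From the compounds shown here alone, the true size of the second step therefore stays unknown, so the data show a shared direction but not whether the change is worth the same on both cores, and two pairs of compounds are too few to make a rule for the whole series.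

The compounds shown carry only dimethylamino and methyl at this place, so it remains open how a simple amino group, a methylamino group or a longer chain such as propyl would fare there. Going by these compounds, they also carry only naphthalen-2-yl and 4-methylphenyl as the neighbouring large group, so it remains open whether the same direction would hold with a plain phenyl or a 4-methoxyphenyl group in its place.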